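A few compounds are considered here, and "the series" means these few. Any claim that something is new, unique, unknown or untested is made for them only; others in the source may bear on it.

In an in vivo ADME assay on the whole organism (Rattus norvegicus, strain Sprague Dawley) for pharmacokinetics (a lower number here means slower removal, a higher number faster removal of the compound), compound 2 `COC(=O)c1ccccc1-c1ccc(CNc2nccc(C)c2NC(=O)CC(F)(F)F)cc1` gives 14 mL/min/kg, numerically the lower of the two numbers in hand, while compound 1 `CNC(=O)c1ccccc1-c1ccc(CNc2ncccc2NC(=O)CC(F)(F)F)cc1` gives 15 mL/min/kg, a gap that falls within the usual scatter of such measurements. Compound 3 `CNC(=O)c1ccccc1-c1ccc(CNc2nccc(C)c2NC(=O)CC(F)(F)F)cc1` has not yet been measured in this assay. It differs from compound 2 in one place: methylamino in place of methoxy on a carbonyl carbon. Within the data shown here, no measured pair shows this change on its own, so no step size can be read from the data. For compound 3 the expected step is no change at the digits printed from compound 2 to compound 3 (within the scatter), that is, nothing beyond the scatter. The estimate for compound 3 in this assay is 14 mL/min/kg, with a range from 7 mL/min/kg to 28 mL/min/kg.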

Compound 3, clearance: 30 mL/min/kg
Beside the measured number, compound 3's estimate is 2.1-fold (0.33 log units) below it, and the stated range ends below it.
By their numbers in this assay, from the lowest: compounds 2, 1 and 3 (each within the scatter of the next, the first and the last beyond it).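

In this assay, methylamino in place of methoxy on a carbonyl carbon brings a 2.1-fold higher number from compound 2 to compound 3 (0.33 log units; beyond the scatter), a modest but real step for this change. Methyl in place of hydrogen on an aromatic carbon brings a 2.0-fold higher number from compound 1 to compound 3 (0.30 log units; within the scatter), so that change does not stand clear of the scatter. Nothing measured here explains either step. On these data alone, whether an ethylamino or dimethylamino group on the same carbonyl carbon would behave like methylamino or like methoxy remains open. So does the effect of an ethyl group or a chlorine atom in place of that aromatic methyl.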